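Three Aryl Variants on a Double-Bonded Chain Carbon

The compounds below may be only part of what the source reports. "The series", "measured", "known", "first", "only" and "open" are said of these compounds alone.

Measured so far:
compound 1, `O=C(CN1CCN(c2cc3c(cc2F)c(=O)c(C(=O)O)cn3C2CC2)CC1)Nc1ccc(C(=O)/C=C/c2ccc(Cl)cc2)cc1`: 2.23 ug/mL
compound 2, `COc1cc(/C=C/C(=O)c2ccc(NC(=O)CN3CCN(c4cc5c(cc4F)c(=O)c(C(=O)O)cn5C4CC4)CC3)cc2)cc(OC)c1OC`: 2.01 ug/mL

In a physicochemical assay for solubility, at pH 7.8 (a lower number here means a less soluble compound, a higher number a more soluble compound), compound 2 gives 2.01 ug/mL, and compound 1 gives 2.23 ug/mL; the two numbers lie within the scatter of each other, so neither stands apart. The change to compound 3, `O=C(CN1CCN(c2cc3c(cc2F)c(=O)c(C(=O)O)cn3C2CC2)CC1)Nc1ccc(C(=O)/C=C/c2cccc([N+](=O)[O-])c2)cc1`, is 3-nitrophenyl in place of 3,4,5-trimethoxyphenyl on a double-bonded chain carbon bound to a double-bonded chain carbon. Going by the values given here, the one measured step that bears on it, an exchange of the aryl group at the same place, gave a 1.1-fold lower number from compound 1 to compound 2 (0.05 log units; within the scatter). Since that exchange left this assay unchanged, the expected step is a 1.0-fold higher number from compound 2 to compound 3 (0.02 log units; within the scatter), none beyond the scatter. Compound 3 is therefore estimated at 2.1 ug/mL, within 1 ug/mL to 4.5 ug/mL.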

Compound 3, solubility: 27.4 ug/mL
The estimate for compound 3 lay 13-fold (1.12 log units) below the measured number; the whole stated range lies below it.
By their numbers in this assay, from the lowest: compounds 2 and 1 (each within the scatter of the next); then compound 3.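

In this assay, the aryl group on a double-bonded chain carbon bound to a double-bonded chain carbon proves able to shift the number strongly, although compound 1 and compound 2 lie within the scatter of each other. 3-Nitrophenyl in place of 3,4,5-trimethoxyphenyl gives a 14-fold higher number from compound 2 to compound 3 (1.13 log units; beyond the scatter), and in place of 4-chlorophenyl it gives a 12-fold higher number from compound 1 to compound 3 (1.09 log units; beyond the scatter). So exchanging this aryl group does not always leave the number unchanged.

From the compounds shown here alone, how an aryl group carrying an amine or a carboxylic acid would behave at this place remains open. Nothing available explains the rise seen with 3-nitrophenyl.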